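Dimethylamino Substitution Across Two Thiadiazole Series

A few compounds are considered here, and "the series" means these few. Any claim that something is new, unique, unknown or untested is made for them only; others in the source may bear on it.

Of the compounds shown here, three have been tested in a functional assay on the whole organism (strain albino) with Rattus norvegicus as the target, in the maximal electroshock model, with a stated time of 1 h, at a dose of 30 mg/kg by the intraperitoneal route; a lower number here means less inhibition, a higher number more inhibition at the dose given (going by the name of the read-out). Compound 2 `Cc1nc2ccc(Br)cc2c(=O)n1NCc1nnc(/N=C/c2ccccc2)s1` gives 50% in this assay. Compound 1 `Cc1nc2ccc(Br)cc2c(=O)n1NCc1nnc(/N=C/c2ccc(N(C)C)cc2)s1` gives 50%, and the change from compound 2 to compound 1, (dimethylamino in place of hydrogen on an aromatic carbon), produces no change at the digits printed from compound 2 to compound 1 (within the scatter). Compound 3 `Cc1nc2ccccc2c(=O)n1NCc1nnc(N2C(=O)CSC2c2ccccc2)s1` gives 60% in this assay, a value within the scatter of both compound 1 and compound 2. The difference between the core of compound 3 and the core of compound 2 is not broken down here.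

Compound 4 `Cc1nc2ccccc2c(=O)n1NCc1nnc(N2C(=O)CSC2c2ccc(N(C)C)cc2)s1` has not yet been measured. It differs from compound 3 by dimethylamino in place of hydrogen on an aromatic carbon, the same change already seen from compound 2 to compound 1. Because that earlier change gave no change at the digits printed from compound 2 to compound 1 (within the scatter), the step from compound 3 to compound 4 is expected to be no change at the digits printed from compound 3 to compound 4 (within the scatter). Compound 4 is therefore estimated at 60%, within a range from 45% to 75%.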

Compound 4, a percentage reported as inhibition, in the whole organism at one dose (the size of the read-out at that dose, not a potency): 60%
Estimate against measurement, compound 4: no gap at the digits printed, and the stated range covers the measured number.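

In this assay, the change from phenyl to 4-(dimethylamino)phenyl produces no change at the digits printed from compound 3 to compound 4 (within the scatter). Set beside the earlier step, the change reads alike on both cores: the same change on two cores in this assay, no change at the digits printed (within the scatter) from compound 2 to compound 1 and no change at the digits printed (within the scatter) from compound 3 to compound 4, 0 percentage points apart, within the scatter of two such steps. This shows that in this read-out the change carried over between the two cores shown without a visible effect, but it rests on a single pair per core at one dose, so it says nothing about potency or about how the change would read on any other core.

The compounds shown carry only hydrogen or dimethylamino at this place on the ring. As far as these compounds go, how a methoxy group, a chlorine atom or a carboxylic acid there would read in this assay remains open.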